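Cyclopropyl for isopropyl on an untested amine

This account rests on a few compounds, and the source may have more. Where it says the series, first, only, none or still open, it means among the compounds named here.

Compound 1 `Nc1nc(OCC(F)(F)F)c2ncn(/C=C3/CC3(CO)CO)c2n1`: > 20000 nM
Compound 2 `CC(C)Nc1nc(N)nc2c1ncn2/C=C1/CC1(CO)CO`: "not determined" (no result reported)

Among the measured compounds shown here, only two compounds sharing one core have entries in an ADME assay on MOLT-3 cells (Homo sapiens) for cytotoxicity, with a stated time of 7 days (on this read-out lower numbers stand for higher toxicity in this test and higher numbers for lower toxicity in this test), and only one of those entries carries a reading. Compound 1 gives > 20000 nM, and this is a limit of the assay, not a number. Compound 2 has no place on the scale, since its entry reads "not determined" (no result reported). The only figure near it is the limit of its relative, so the starting point for the step is open.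

Compound 3 `Nc1nc(NC2CC2)c2ncn(/C=C3/CC3(CO)CO)c2n1` has yet to be measured. The structural change is a single exchange, with isopropylamino becoming cyclopropylamino: cyclopropyl in place of isopropyl on a nitrogen on an aromatic ring. For the measured compounds named here, no measured step between related compounds gives this exchange a size, and compound 2 offers no value to start from. No shift beyond the usual scatter is therefore expected in this assay, in either direction. Going by the values given here, the reading of compound 1 remains the only guide, and low toxicity in this test is expected to hold. The estimate for compound 3 is 25000 nM, with an expected range from 8000 nM to 80000 nM.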

Compound 3, half-maximal cytotoxic concentration: > 20000 nM
Compound 3 ended at the assay's limit (the forecaster's own chance of this, stated with the estimate: 60%); the middle value does not contradict the limit.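

No step can be read from compound 1 to compound 3 in this assay, since both readings are limits of the assay and not numbers: the limit of > 20000 nM in this assay, at which 2 of the 3 values shown sit.

The compounds shown leave open how far either compound lies past that limit, and whether cyclopropylamino in place of isopropylamino, from compound 2 to compound 3, changes the reading in this assay at all.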